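Arylsulfonate anilides: chloro on the butanamide chain

The source may report more compounds than this note shows. Statements on the series, on what has been measured and on what is new or still open speak of the compounds shown alone.

Measured so far:
compound 1 `CC(C)c1ccccc1OS(=O)(=O)c1cccc(NC(=O)CCCl)c1`, 11000 nM
compound 2 `CCCC(=O)Nc1ccc(S(=O)(=O)Oc2ccccc2C(C)C)cc1`, 4900 nM
compound 3 `CCCC(=O)Nc1ccc(S(=O)(=O)Oc2ccccc2I)cc1`, 11000 nM

In a functional assay on HT-29 cells (Homo sapiens) for antiproliferative activity, read by sulforhodamine B assay, with a stated time of 48 h (a higher number here means a weaker inhibitor, a lower number a stronger inhibitor), compound 3 gives 11000 nM. This stands level with compound 1 at the digits shown, and the two together are the highest of the three numbers; compound 2, the nearest other point, sits a step away, seen as a 2.2-fold higher number from compound 2 to compound 3 (0.35 log units; beyond the scatter) for iodo in place of isopropyl on an aromatic carbon.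

Compound 4 `O=C(CCCCl)Nc1ccc(S(=O)(=O)Oc2ccccc2I)cc1` is the next point. It differs from compound 3 by chloro in place of hydrogen on a saturated chain carbon, three bonds along the chain from a carbonyl carbon. For the measured compounds named here, none of the measured steps bears on this change: the one step with a single difference, from compound 2 to compound 3, concerns the aromatic substituent, not the amide chain. Compound 1 carries a chloro on a shorter chain together with a different amide placement and a different aromatic substituent, so its value and that of compound 3 cannot be read as a step.

With nothing to anchor the chloro substitution, the expectation for compound 4 is a step of a 1.2-fold lower number from compound 3 to compound 4 (0.09 log units; within the scatter), that is, none beyond the scatter. Compound 4 is therefore estimated at 9000 nM in this assay, within the range 3500 nM to 25000 nM.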

Compound 4, half-maximal inhibitory concentration: 9100 nM
Compound 4: the middle estimate sits 1.0-fold (0.00 log units) below what was measured; low and high end bracket the measured number.
By their numbers in this assay, from the lowest: compounds 2, 4, 1 and 3 (each within the scatter of the next, the first and the last beyond it).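

In this assay, for the compounds shown here, this is the first reading on the amide chain with everything else held fixed: a 1.2-fold lower number from compound 3 to compound 4 (0.08 log units; within the scatter). Propyl to 3-chloropropyl therefore leaves the number within the scatter with iodo as the aromatic substituent, whereas the earlier step from isopropyl to iodo addressed only the aromatic side. No evidence at hand accounts for this result.

Whether chloro at this chain carbon gives a similar reading with isopropyl in place of iodo remains open, since compound 2 has no chloro partner among the compounds shown. Also open, as far as these compounds go, is what an amine or a carboxylic acid at this chain carbon, or a longer chain carrying the chloro, would give.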